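Branching the Butyl Chain of Compound 1

This account rests on a few compounds, and the source may have more. Where it says the series, first, only, none or still open, it means among the compounds named here.

Among the compounds with values here, in an ADME assay on HepG2 cells (Homo sapiens) for cytotoxicity, read by CellTiter-Glo, with a stated time of 48 h (a lower number here means that less compound is tolerated, a higher number that more compound is tolerated), compound 1 (`CCCCNc1nc2ccc(OC)cc2nc1S(C)(=O)=O`) gives 20000 nM as the only exact number so far. Compound 2 (`CCCCNc1nc2cc(OC)ccc2nc1S(C)(=O)=O`) gives > 100000 nM in the same test, and this is a limit of the assay. Compound 3 (`COc1ccc2nc(NCC(C)C)c(S(C)(=O)=O)nc2c1`) is still unmeasured. It has isopropyl in place of propyl on a saturated chain carbon bound to a nitrogen on an aromatic ring, which turns butylamino into isobutylamino (isopropyl in place of propyl on a saturated chain carbon bound to a nitrogen on an aromatic ring). Within the data shown here, no measured pair shows this kind of change, so in this assay the expected step of no change at the digits printed from compound 1 to compound 3 (within the scatter) is none beyond the usual scatter. Compound 3 is estimated at 20000 nM with an expected range from 8000 nM to 60000 nM when tested.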

Compound 3, half-maximal cytotoxic concentration: 12600 nM
For compound 3 the middle estimate is 1.6-fold (0.20 log units) above the measured one, within the range that was stated.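

In this assay, within the data shown here, turning butylamino into isobutylamino gives a 1.6-fold lower number from compound 1 to compound 3 (0.20 log units; within the scatter) and is the first reading of a change on this chain. At this saturated chain carbon, propyl and isopropyl cannot be told apart in this test, so this branching leaves the cell result where it was within the scatter. Nothing measured here gives a cause for this result.

From the compounds shown here alone, whether a longer chain, a cyclopropyl ring or a terminal amine would read the same at this place stays open. So does whether isobutylamino would behave alike on the core of compound 2.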